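A few compounds are considered here, and "the series" means these few. Any claim that something is new, unique, unknown or untested is made for them only; others in the source may bear on it.

Measured compounds: compound 1 `CC(C)(C)OC(=O)NCCCCNCCCN(Cc1ccsc1)Cc1ccsc1` gives 16400 nM; compound 2 `CC(C)(C)OC(=O)NCCCCNCCCN(Cc1ccc(OCc2ccccc2)cc1)Cc1ccc(OCc2ccccc2)cc1` gives 33300 nM; compound 3 `NCCCCNCCCN(Cc1ccsc1)Cc1ccsc1` gives 52800 nM. All three were tested in an ADME assay on RAW264.7 cells (Mus musculus) for cytotoxicity, read by resazurin assay, with a stated time of 48 h; a lower number here means that less compound is tolerated, a higher number that more compound is tolerated.

Compound 1 and compound 3 share a core and differ in one place, (hydrogen in place of tert-butoxycarbonyl on an amine nitrogen), and this change made a 3.2-fold higher number from compound 1 to compound 3 (0.51 log units; beyond the scatter). The cores of compound 1 and compound 2 differ, but that difference is not broken down here. Compound 4 `NCCCCNCCCN(Cc1ccc(OCc2ccccc2)cc1)Cc1ccc(OCc2ccccc2)cc1` has not yet been measured; it differs from compound 2 in the same way, (hydrogen in place of tert-butoxycarbonyl on an amine nitrogen), at a place described in the same words. Since the change occurs only twice among these compounds, the expectation rests on a single precedent: the step from compound 2 to compound 4 is expected to be about a 3.0-fold higher number from compound 2 to compound 4 (0.48 log units; beyond the scatter), similar to the step from compound 1 to compound 3. The value of compound 4 is accordingly estimated at 100000 nM, with a range from 50000 nM to 200000 nM.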

Compound 4, half-maximal cytotoxic concentration: > 100000 nM
Compound 4 gave a limit, no number; the forecaster's own chance of this, stated with the estimate: 25%; the middle value lies on the limit itself.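

In this assay, hydrogen in place of tert-butoxycarbonyl on an amine nitrogen gave an at least 3.0-fold higher number from compound 2 to compound 4 (0.47 log units; beyond the scatter) on the second core, the same direction as on the first. Compound 4 gives > 100000 nM as a limit of the assay, not a number. The direction of the change therefore carried over from one core to the other, but the two cores are the only cases here and no claim can be made that the size of the step is the same: the same change on two cores in this assay, a 3.2-fold higher number (0.51 log units; beyond the scatter) from compound 1 to compound 3 and an at least 3.0-fold higher number (0.47 log units; beyond the scatter) from compound 2 to compound 4; the limit leaves it open whether they differ.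

The compounds shown leave open what an acetyl or a methyl group in place of tert-butoxycarbonyl on that amine nitrogen would give. They also leave open what a longer chain would give on either core.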